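Adding One Methoxy Group to Compound 2

This account rests on a few compounds, and the source may have more. Where it says the series, first, only, none or still open, it means among the compounds named here.

In a functional assay on A549 cells (Homo sapiens) for inhibition, read by MTT assay, with a stated time of 24 h (on this read-out higher numbers stand for weaker inhibition of growth and lower numbers for stronger inhibition of growth), compound 1 (`COc1cc(C(=O)n2c(-c3cn(C)c4ccccc34)nc3ccccc32)cc(OC)c1OC`) gives 2600 nM and compound 2 (`COc1ccc2c(c1)c(-c1nc3ccccc3n1C(=O)c1ccc(OC)c(OC)c1)cn2C`) gives 2700 nM. These two values lie within the usual scatter of repeated measurements, so compound 2 stands level with compound 1. The two compounds differ in more than one place, so their values cannot be tied to any single structural change.

Compound 3 (`COc1ccc2c(c1)c(-c1nc3ccccc3n1C(=O)c1cc(OC)c(OC)c(OC)c1)cn2C`) differs from compound 2 by one change: methoxy in place of hydrogen on an aromatic carbon. Among the compounds with values here, that aromatic ring then matches the one in compound 1, while the rest of compound 3 matches compound 2.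

Within the data shown here, no measured step isolates this change, so any expectation rests on thin evidence. Compound 1 already carries that ring and reads 2600 nM, which gives no sign of a large effect in this assay. A small move toward stronger inhibition of growth is expected, possibly no larger than the scatter. The expected change is a 1.7-fold lower number from compound 2 to compound 3 (0.23 log units; within the scatter).

For compound 3 the estimated value is 1600 nM, with an expected range from 400 nM to 4000 nM.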

Compound 3, concentration for 50% growth inhibition: 2400 nM
Compound 3: middle estimate off by 1.5-fold (0.18 log units), on the low side; low and high end bracket the measured number.
By their numbers in this assay, from the lowest: compounds 3, 1 and 2 (each within the scatter of the next).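

The swap of hydrogen for methoxy at this position, on an aromatic carbon ortho to a methoxy group and meta to a large group, comes to a 1.1-fold lower number from compound 2 to compound 3 (0.05 log units; within the scatter) in this assay, so this position accepts the extra methoxy with no difference from compound 2 that can be told from the scatter. The same swap at a different place on the molecule, the one aromatic carbon that separates these two compounds, comes to a 1.1-fold lower number from compound 1 to compound 3 (0.03 log units; within the scatter) in this assay, which means that neither of these two single additions moves the reading beyond the scatter, and the three compounds stand level. No other measurement here bears on why the numbers stay level.

Hydrogen and methoxy are the only two groups shown at this position, so it remains open whether a group of a different kind, such as an amine, a carboxylic acid or a longer chain like butoxy, would leave the reading just as level. From the compounds shown here alone, it also remains open whether removing the other methoxy groups on this ring would shift the number beyond the scatter.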